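A few compounds are considered here, and "the series" means these few. Any claim that something is new, unique, unknown or untested is made for them only; others in the source may bear on it.

Measured so far in a functional assay on HepG2 cells (Homo sapiens) for cytotoxicity, read by MTT assay, with a stated time of 48 h; a lower number here means a stronger inhibitor, a higher number a weaker inhibitor:
Compound 1, `CC(=O)OC[C@H]1O[C@H](NS(N)(=O)=O)C=C[C@@H]1OC(C)=O`, gives 336000000 nM.
Compound 2, `CC(=O)OC[C@H]1O[C@H](NS(=O)(=O)c2ccc(C)cc2)C(OC(C)=O)=C[C@@H]1OC(C)=O`, gives 39200000 nM.
Compound 3, `CC(=O)OC[C@H]1O[C@H](NS(=O)(=O)c2ccc(C)cc2)C=C[C@H]1OC(C)=O`, gives 307000000 nM.

Among these three, compound 2 carries the lowest number, and its gaps to compound 3 and to compound 1 both lie beyond the usual scatter, so compound 2 counts as the strongest inhibitor of the set, though all three numbers are very high. Compound 4, `CCS(=O)(=O)N[C@H]1O[C@H](COC(C)=O)[C@@H](OC(C)=O)C=C1OC(C)=O`, has not been measured. It differs from compound 2 by ethyl in place of 4-methylphenyl on a sulfonyl sulfur. Among the measured compounds shown here, no measured pair shows this change on its own, so the expectation rests only on the spread seen here. Compound 4 is expected to give a higher number than compound 2, a step of about a 3.8-fold higher number from compound 2 to compound 4 (0.58 log units; beyond the scatter). The estimate for compound 4 in this assay is 150000000 nM, within 40000000 nM to 500000000 nM.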

Compound 4, half-maximal inhibitory concentration: 14700000 nM
For compound 4 the middle estimate is 10-fold (1.01 log units) above the measured one, and the stated range ends above it.
By their numbers in this assay, from the lowest: compound 4; then compound 2; then compounds 3 and 1 (each within the scatter of the next).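

In this assay, the aromatic ring on the sulfonyl sulfur turns out not to be required: ethyl in place of 4-methylphenyl gives a 2.7-fold lower number from compound 2 to compound 4 (0.43 log units; beyond the scatter), a modest step. The smaller group, with no ring, therefore does better here than the larger one, the reverse of what the earlier spread suggested. Nothing available explains why this swap lowers the number.

From the compounds shown here alone, how the number moves with methyl, a longer chain such as butyl, or an unsubstituted phenyl on the same sulfur stays open. A single step also cannot separate losing the ring from shortening the group.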